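Amine substituent step in a diphenylamine ether series

A few compounds are considered here, and "the series" means these few. Any claim that something is new, unique, unknown or untested is made for them only; others in the source may bear on it.

Measured compounds:
compound 1, `COc1ccc(CCCNCc2c(OC)cc(Oc3ccc(Nc4ccccc4)cc3)cc2OC)cc1`: 2180 nM
compound 2, `COc1cc(Oc2cccc(Nc3ccccc3)c2)cc(OC)c1CNC1CC1`: 6140 nM

In a functional assay on HCT-15 cells (Homo sapiens) for inhibition, read by MTT assay, with a stated time of 72 h (on this read-out higher numbers stand for weaker inhibition and lower numbers for stronger inhibition), compound 2 gives the higher of the two numbers, with compound 1 the nearer at a lower number, a gap beyond the scatter. Compound 3, `COc1cc(Oc2cccc(Nc3ccccc3)c2)cc(OC)c1CNCc1ccc(C)cc1`, differs from compound 2 only here: 4-methylbenzyl in place of cyclopropyl on an amine nitrogen. Going by the values given here, no step between measured compounds covers this change. A moderate drop in the number is expected, a 2.0-fold lower number from compound 2 to compound 3 (0.31 log units; beyond the scatter), since compound 1 with an aryl-bearing amine substituent gives 2180 nM. For compound 3 the expected value is 3000 nM, within 1200 nM to 8000 nM.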

Compound 3, half-maximal inhibitory concentration: 5400 nM
Compound 3: middle estimate off by 1.8-fold (0.26 log units), on the low side; the measured number falls inside the stated range.
By their numbers in this assay, from the lowest: compound 1; then compounds 3 and 2 (each within the scatter of the next).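

In this assay, the step of a 1.1-fold lower number from compound 2 to compound 3 (0.06 log units; within the scatter) shows that, on this amine nitrogen, replacing cyclopropyl with 4-methylbenzyl does not separate the two compounds on the shared core. Compound 1 differs from both in more than one place, so its value cannot be read as an effect of this substituent. No supporting data bear on why the step is so small. Still open, on these data alone, is whether a 2-hydroxyethyl group, or a carboxylic acid on the benzyl ring, would move the number beyond the scatter at this nitrogen.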